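Shortening the chain and swapping the terminal ring in compound 4

The source may report more compounds than this note shows. Statements on the series, on what has been measured and on what is new or still open speak of the compounds shown alone.

Compound 1 `CN1CCN(CCCCn2c3c(c4ccccc42)C(=O)c2c[n+]([O-])c4ccccc4c2C3=O)CC1` gives the lowest number of the three measured compounds in a functional assay on MDA-MB-231 cells (Homo sapiens) for cytotoxicity, read by MTT assay, with a stated time of 72 h (on this read-out higher numbers stand for weaker inhibition and lower numbers for stronger inhibition), at 110 nM. Compound 2 `O=C1c2c[n+]([O-])c3ccccc3c2C(=O)c2c1c1ccccc1n2CCCCN1CCNCC1` gives 3310 nM and compound 3 `CN1CCN(CCCCCCn2c3c(c4ccccc42)C(=O)c2c[n+]([O-])c4ccccc4c2C3=O)CC1` gives 2400 nM. Compound 4 `O=C1c2c[n+]([O-])c3ccccc3c2C(=O)c2c1c1ccccc1n2CCCN1CCC(O)CC1` differs from compound 1 by 4-hydroxypiperidin-1-yl in place of (4-methylpiperazin-1-yl)methyl on a saturated chain carbon, three bonds along the chain from an aromatic nitrogen. Among the compounds with values here, two measured steps bear on this: a 30-fold higher number from compound 1 to compound 2 (1.48 log units; beyond the scatter), and a 22-fold higher number from compound 1 to compound 3 (1.34 log units; beyond the scatter); both changes at the chain terminus or its length weakened inhibition strongly. Within the data shown here, compound 4 alters both the chain length and the ring, so a step toward a higher number is expected, a 14-fold higher number from compound 1 to compound 4 (1.13 log units; beyond the scatter), though no measured pair shows this exact change. Compound 4 is therefore estimated at 1500 nM, within a range of 300 nM to 8000 nM.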

Compound 4, half-maximal inhibitory concentration: 280 nM
Compound 4: the middle estimate sits 5.4-fold (0.73 log units) above what was measured; the whole stated range lies above it.
By their numbers in this assay, from the lowest: compound 1; then compound 4; then compounds 3 and 2 (each within the scatter of the next).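

In this assay, the 4-hydroxypiperidin-1-yl ring on a chain one carbon shorter costs far less than the changes seen earlier at this position: a 2.5-fold higher number from compound 1 to compound 4 (0.41 log units; beyond the scatter). Set against the other two side chains, the same kind of change lowers the number, with an 8.6-fold lower number from compound 3 to compound 4 (0.93 log units; beyond the scatter) and a 12-fold lower number from compound 2 to compound 4 (1.07 log units; beyond the scatter). Nothing available explains these steps.

Chain length and terminal ring change together here, so their shares remain open. A propyl chain ending in 4-methylpiperazin-1-yl, or a butyl chain ending in 4-hydroxypiperidin-1-yl, would separate them.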